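The source may report more compounds than this note shows. Statements on the series, on what has been measured and on what is new or still open speak of the compounds shown alone.

Compound 2 `O=C(/N=C(/NC(=O)c1ccno1)[Se]Cc1ccccc1)c1ccno1` and compound 3 `O=C(/N=C(/NC(=O)c1cccs1)[Se]Cc1ccccc1)c1cccs1` share a benzylselanyl group on the central carbon and differ in their cores; the difference between the two cores is not broken down here. In a functional assay on K562 cells (Homo sapiens) for cytotoxicity, read by MTT assay, with a stated time of 72 h (a higher number here means a weaker inhibitor of growth, a lower number a stronger inhibitor of growth), compound 2 gives 57300 nM. In this assay compound 3 gives 58500 nM, and the two values lie within the scatter of each other. Compound 1 `CS/C(=N\C(=O)c1ccno1)NC(=O)c1ccno1` carries the smaller group instead: a group of 2 heavy atoms (1 carbon, 1 sulfur; no ring) in place of a group of 8 heavy atoms (7 carbon, 1 selenium; one six-membered aromatic ring of carbon only), on a carbon with a double bond to nitrogen. For compound 1 this assay reports only a limit, > 100000 nM. The step from compound 2 to compound 1 is therefore known only as a floor, an at least 1.7-fold higher number from compound 2 to compound 1 (0.24 log units; that floor lies within the scatter), because the limit of > 100000 nM in this assay, at which 1 of the 3 values shown sits, describes the value of compound 1.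

Compound 4 `CS/C(=N\C(=O)c1cccs1)NC(=O)c1cccs1` is the counterpart of compound 3 with the same change made on the same core: a group of 2 heavy atoms (1 carbon, 1 sulfur; no ring) in place of a group of 8 heavy atoms (7 carbon, 1 selenium; one six-membered aromatic ring of carbon only), on a carbon with a double bond to nitrogen. Going by the values given here, the two places are described in the same words, so this is the same change as the one from compound 2 to compound 1. The expectation for compound 4 rests on that measured pair, with compound 3 giving 58500 nM in this assay as the starting point. The same replacement in compound 2 led to a value for which this assay reports only a limit, so a weakening of at least the same size is expected, a 1.9-fold higher number from compound 3 to compound 4 (0.27 log units; within the scatter). Compound 4 is therefore estimated at 110000 nM in this assay, with a likely range from 50000 nM to 300000 nM, and it is quite possible that only a limit will be reported for compound 4.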

Compound 4, concentration for total growth inhibition: > 100000 nM
Compound 4 ended at the assay's limit; the forecaster's own chance of this, stated with the estimate: 65%; the middle value is on the limit's open side.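

Carried onto the core of compound 3, the replacement of the benzylselanyl group by methylsulfanyl gives an at least 1.7-fold higher number from compound 3 to compound 4 (0.23 log units; that floor lies within the scatter), so this step, like the earlier one, is known only as a floor. Set beside the earlier pair, the two steps agree as far as they can be read: the same change on two cores in this assay, an at least 1.7-fold higher number (0.24 log units; that floor lies within the scatter) from compound 2 to compound 1 and an at least 1.7-fold higher number (0.23 log units; that floor lies within the scatter) from compound 3 to compound 4; the limit leaves it open whether they differ. From the compounds shown here alone, both changes end at the same limit, which fits the change carrying over from one core to the other, but it does not show that the step has the same size on both cores or that either step goes beyond the scatter, and the actual values of compound 1 and compound 4 stay unknown: the limit of > 100000 nM in this assay, at which 2 of the 4 values shown sit.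

The change removes the selenium and the carbon ring together, so these pairs do not tell which of the two parts matters in this assay, and a benzylsulfanyl group or a methylselanyl group on the central carbon would separate them. Also open, going by these compounds, is how this assay would respond to other groups at that place, such as an amine or a longer chain on the sulfur.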